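This account rests on a few compounds, and the source may have more. Where it says the series, first, only, none or still open, it means among the compounds named here.

Notes on the series. Within the data shown here, compound 1 `Cc1ccccc1OCCCCCn1ccc(=O)[nH]c1=O` is the only member with a result in an ADME assay on HEL cells (Homo sapiens) for cytotoxicity; on this read-out lower numbers stand for higher toxicity in this test and higher numbers for lower toxicity in this test; for compound 1 the assay reports a limit rather than a number, > 100000 nM, and the whole evidence on this read-out is the limit of > 100000 nM in this assay, at which 1 of the 3 values shown sits. Compound 2 `O=c1ccn(CCCCOc2ccc(Br)cc2)c(=O)[nH]1` carries "not determined" (no result reported) in this assay. Compound 3 `O=c1ccn(CCCOc2ccc(Br)cc2)c(=O)[nH]1` likewise carries "not determined" (no result reported) in this assay. Compound 4 `Cc1cccc(OCCCCCn2ccc(=O)[nH]c2=O)c1` is still to be measured in this assay; it differs from compound 1 by 3-methylphenyl in place of 2-methylphenyl on an oxygen on a saturated carbon. Among the measured compounds shown here, no step between measured compounds exists in this assay, so the expected step of a number no higher from compound 1 to compound 4 (the limit leaves the size open) is none beyond the scatter. Compound 4 is estimated at 100000 nM, within 50000 nM to 200000 nM, and the result is expected most likely to be a limit again.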

Compound 4, half-maximal cytotoxic concentration: > 100000 nM
Compound 4: a limit, no number; the forecaster's own chance of this, stated with the estimate: 80%; the middle value sits exactly at the limit.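

Among these compounds, compound 1 and compound 4 each give only a limit in this assay, so no step between them can be read: the limit of > 100000 nM in this assay, at which 2 of the 4 values shown sit.

The compounds shown leave open whether 3-methylphenyl in place of 2-methylphenyl changes cytotoxicity at all.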